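Swapping a Hydroxybenzyl Ether for a Hydroxycyclohexyl Ether

The source may report more compounds than this note shows. Statements on the series, on what has been measured and on what is new or still open speak of the compounds shown alone.

Measured compounds:
compound 1 `O=S(=O)(NCCNC(=S)Nc1cc(C(F)(F)F)cc(C(F)(F)F)c1)c1ccc(-c2ccccc2OCc2cccc(O)c2)s1`: 12000 nM
compound 2 `Cc1ccc(-c2ccsc2S(=O)(=O)NCCNC(=O)Nc2cc(C(F)(F)F)cc(C(F)(F)F)c2)c(Oc2ccc(O)c(O)c2)c1`: 5600 nM

In a functional assay on RS4-11 cells (Homo sapiens) for inhibition, read by CCK-8 assay, with a stated time of 48 h (a lower number here means a stronger inhibitor, a higher number a weaker inhibitor), compound 1 gives the higher of the two numbers; compound 2 gives the lower one, and the gap between them lies beyond the scatter. Compound 3 `O=S(=O)(NCCNC(=S)Nc1cc(C(F)(F)F)cc(C(F)(F)F)c1)c1ccc(-c2ccccc2O[C@H]2CC[C@@H](O)CC2)s1` has not been measured. It differs from compound 1 in one place: 4-hydroxycyclohexyl in place of 3-hydroxybenzyl on an oxygen on an aromatic ring. Among the measured compounds shown here, no measured pair shows this change, so the size of its step is open. In this assay the change is expected to move the number little, with no step beyond the scatter, giving a 1.1-fold lower number from compound 1 to compound 3 (0.04 log units; within the scatter). Compound 3 is therefore estimated at 11000 nM, within 3500 nM to 35000 nM.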

Compound 3, half-maximal inhibitory concentration: 6300 nM
Beside the measured number, compound 3's estimate is 1.7-fold (0.24 log units) above it; the range from low to high includes it.
By their numbers in this assay, from the lowest: compounds 2, 3 and 1 (each within the scatter of the next, the first and the last beyond it).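

In this assay, the one-place swap gives a 1.9-fold lower number from compound 1 to compound 3 (0.28 log units; within the scatter), so on this oxygen on an aromatic ring a non-aromatic 4-hydroxycyclohexyl stands in for 3-hydroxybenzyl with no step beyond the scatter. At this position, then, the aromatic ring of the leaving group is not needed to hold the number at this level. Nothing available here accounts for the result.

The compounds shown leave open whether the hydroxyl matters, as a plain cyclohexyl group would test. They also leave open how an amine or a carboxylic acid at that ring position would read.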